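Adding a second trifluoromethyl to compound 1

A few compounds are considered here, and "the series" means these few. Any claim that something is new, unique, unknown or untested is made for them only; others in the source may bear on it.

- compound 1 `O=C(Nc1ccc2c(c1)B(O)OC2)c1ccccc1C(F)(F)F` gives 2100 nM
- compound 2 `O=C(Nc1ccc2c(c1)B(O)OC2)c1ccccc1-c1ccccc1` gives > 100000 nM (a limit of the assay)
- compound 3 `O=C(Nc1ccc2c(c1)B(O)OC2)c1cc(F)ccc1C(F)(F)F` gives 11000 nM

In a functional assay on PBMC cells (Homo sapiens) for inhibition, read by HTRF, with stated times of 15 min and 24 h (on this read-out higher numbers stand for weaker inhibition and lower numbers for stronger inhibition), compound 1 gives 2100 nM as the lowest number shown, so it is the strongest inhibitor of the three. Compound 4 `O=C(Nc1ccc2c(c1)B(O)OC2)c1ccc(C(F)(F)F)cc1C(F)(F)F` differs from it by one change, (trifluoromethyl in place of hydrogen on an aromatic carbon), which places trifluoromethyl in place of hydrogen on an aromatic carbon. The closest measured change is fluoro in place of hydrogen, a modest step of a 5.2-fold higher number from compound 1 to compound 3 (0.72 log units; beyond the scatter) in the weaker direction. Phenyl in place of trifluoromethyl gave a large step of an at least 47-fold higher number from compound 1 to compound 2 (1.67 log units; beyond the scatter) in that same direction. A modest rise, meaning weaker inhibition, is therefore expected in this assay. The expected step is a 4.3-fold higher number from compound 1 to compound 4 (0.63 log units; beyond the scatter) overall. Compound 4 is estimated at 9000 nM, with an expected range of 2500 nM to 40000 nM.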

Compound 4, half-maximal inhibitory concentration: 5300 nM
Compound 4: middle estimate off by 1.7-fold (0.23 log units), on the high side; the range from low to high includes it.
By their numbers in this assay, from the lowest: compound 1; then compound 4; then compound 3. At a limit, above all of these: compound 2.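

Placing trifluoromethyl on this ring carbon, para to a large group and meta to a trifluoromethyl group, weakens inhibition only modestly in this assay, with a 2.5-fold higher number from compound 1 to compound 4 (0.40 log units; beyond the scatter). This shows that a group of four heavy atoms at this position leaves a measurable effect, although hydrogen remains the better of the two. Nothing measured here explains the loss. As far as these compounds go, whether an amine, a carboxylic acid or a methoxy group on this same carbon would match or surpass hydrogen remains open.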